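A few compounds are considered here, and "the series" means these few. Any claim that something is new, unique, unknown or untested is made for them only; others in the source may bear on it.

Compound 1 `COc1cc(Cl)cc(-c2nn(-c3cccc(NC(=O)c4ccc(Cl)c(Cl)c4)c3)cc2-c2ccncc2)c1` stands highest of the three measured compounds in a functional assay on MCF7 cells (Homo sapiens) for inhibition, read by sulforhodamine B assay, with a stated time of 48 h, tested at 10 uM (a higher number here means a weaker effect of the compound at the concentration tested, a lower number a stronger effect), where compound 1 gives 57.7%. Compound 2 `COc1cc(Cl)cc(-c2nn(-c3cccc(NC(=O)Nc4ccc(Cl)c(C(F)(F)F)c4)c3)cc2-c2ccncc2)c1` gives 2.57% in this assay, and compound 3 `COc1cc(Cl)cc(-c2nn(-c3cccc(NC(=O)Nc4cc(C(F)(F)F)cc(C(F)(F)F)c4)c3)cc2-c2ccncc2)c1` gives 3.81%. Within the data shown here, the one measured step that touches the carbonyl carbon, a number 55.1 percentage points lower from compound 1 to compound 2 (beyond the scatter), combines the change to a carbamoyl linkage with a different aryl group. Compound 4 `COc1cc(Cl)cc(-c2nn(-c3cccc(NC(=O)Nc4ccc(Cl)c(Cl)c4)c3)cc2-c2ccncc2)c1` is reached from compound 1 by (3,4-dichlorophenyl)amino in place of 3,4-dichlorophenyl on a carbonyl carbon. Because compound 2 gives 2.57% and compound 3 gives 3.81% with the same carbamoyl linkage, the expected step is large and downward, a number 51.7 percentage points lower from compound 1 to compound 4 (beyond the scatter). Compound 4 is estimated to give 6% in this assay, within a range from 0% to 30%.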

Compound 4, a percentage reported as activity, at one concentration (the size of the read-out at that concentration, not a potency): 4.66%
Compound 4: the middle estimate sits 1.3 percentage points above what was measured; low and high end bracket the measured number.
By their numbers in this assay, from the lowest: compounds 2, 3 and 4 (each within the scatter of the next); then compound 1.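

With the 3,4-dichlorophenyl group held fixed, the step in this assay reads a number 53 percentage points lower from compound 1 to compound 4 (beyond the scatter), so the large drop belongs to (3,4-dichlorophenyl)amino in place of 3,4-dichlorophenyl on a carbonyl carbon alone, which the earlier step, with its different aryl group, could not separate. For chloro in place of trifluoromethyl on an aromatic carbon the step reads a number 2.1 percentage points higher from compound 2 to compound 4 (within the scatter), so this exchange on the aryl group shows no separable effect here. Nothing available explains the drop. The compounds shown leave open how an N-methyl group on that amino nitrogen would read, which would remove the amide hydrogen. They also leave open whether a methylene chain between the carbonyl carbon and the 3,4-dichlorophenyl group would keep the low number.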